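The compounds below may be only part of what the source reports. "The series", "measured", "known", "first", "only" and "open" are said of these compounds alone.

Compound 1 `O=C(O)Cc1sc(C(c2ccc(F)cc2)c2ccc(F)cc2)nc1-c1cc(F)cc(F)c1`: 340 nM. Compound 2 `COc1cc(-c2nc(C(c3ccc(F)cc3)c3ccc(F)cc3)sc2CC(=O)O)ccn1`: 380 nM. Compound 3 `O=C(O)Cc1sc(C(c2ccc(F)cc2)c2ccc(F)cc2)nc1-c1ccncc1`: 40 nM.

The three compounds share one core and differ only in the aromatic group attached to it. In an in vitro functional assay on HEK285-7 cells for antagonist activity at prostaglandin D2 receptor 2 (Homo sapiens), read by BRET and beta-arrestin recruitment (on this read-out lower numbers stand for stronger inhibition and higher numbers for weaker inhibition), compound 3 gives the lowest number of the three: the steps of an 8.5-fold lower number from compound 1 to compound 3 (0.93 log units; beyond the scatter) and a 9.5-fold lower number from compound 2 to compound 3 (0.98 log units; beyond the scatter) both set it apart beyond the scatter, while a 1.1-fold higher number from compound 1 to compound 2 (0.05 log units; within the scatter) stays within the scatter. Compound 4 `O=C(O)Cc1sc(C(c2ccc(F)cc2)c2ccc(F)cc2)nc1-c1cn[nH]c1` has not been measured; it differs from compound 3 by 1H-pyrazol-4-yl in place of pyridin-4-yl on an aromatic carbon. Going by the values given here, no measured step exchanges one nitrogen-containing ring for another, so the known steps show only that this group matters a good deal without telling the direction here. Compound 4 is estimated to give 90 nM, a step of a 2.3-fold higher number from compound 3 to compound 4 (0.35 log units; beyond the scatter), with an expected range from 25 nM to 350 nM.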

Compound 4, half-maximal inhibitory concentration: 220 nM
Estimate against measurement, compound 4: 2.4-fold (0.39 log units) below; the measured number falls inside the stated range.
By their numbers in this assay, from the lowest: compound 3; then compounds 4, 1 and 2 (each within the scatter of the next).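

Exchanging one nitrogen-containing ring for another is not neutral at this position: in a 5.5-fold higher number from compound 3 to compound 4 (0.74 log units; beyond the scatter) the 1H-pyrazol-4-yl group does not match pyridin-4-yl. Compound 4 instead falls in with the other two, as a 1.7-fold lower number from compound 2 to compound 4 (0.24 log units; within the scatter) and a 1.5-fold lower number from compound 1 to compound 4 (0.19 log units; within the scatter) both stay within the scatter, so a nitrogen in the ring is not enough to match compound 3. Nothing available explains the gap between these two rings.

Still open, as far as these compounds go, is how a pyridin-3-yl or a 1-methyl-1H-pyrazol-4-yl group would compare with pyridin-4-yl at this position.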